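Chain extension at the hydroxyalkyl amide of compound 1

This account rests on a few compounds, and the source may have more. Where it says the series, first, only, none or still open, it means among the compounds named here.

Compound 1 `COc1cccc2cc(C(=O)NCCO)c(=N)oc12` gives the higher of the two numbers measured in an assay on CHO cells for displacement of a labelled ligand from adenosine receptor A1 (Homo sapiens), read by scintillation counting, with a stated time of 60 min, tested at 10 uM; a higher number here means more inhibition at the concentration tested (going by the name of the read-out), a lower number less inhibition. In this assay compound 1 gives 47%. Compound 2 `O=C(NCCCO)c1cc2ccccc2oc1=O` differs from it in more than one place, and in this assay compound 2 gives 24%, a gap beyond the usual scatter; those two values are all that can be said of the pair. The unmeasured compound 3 `COc1cccc2cc(C(=O)NCCCCCO)c(=N)oc12` keeps the core of compound 1 and changes only the amide side chain: 3-hydroxypropyl in place of hydroxy on a saturated chain carbon, two bonds along the chain from an amide-type nitrogen. Going by the values given here, no step between measured compounds tells how this assay responds to such a change, so the direction is open. A modest drop, or no change beyond the scatter, is the expectation, and the step from a number 7 percentage points lower from compound 1 to compound 3 (within the scatter) is estimated accordingly. Compound 3 is expected to give 40%, within a range from 15% to 65%.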

Compound 3, a percentage reported as inhibition, at one concentration (the size of the read-out at that concentration, not a potency): 44%
For compound 3 the middle estimate is 4 percentage points below the measured one, and the stated range covers the measured number.
By their numbers in this assay, from the lowest: compound 2; then compounds 3 and 1 (each within the scatter of the next).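

Putting 3-hydroxypropyl in place of hydroxy on a saturated chain carbon, two bonds along the chain from an amide-type nitrogen, gives a number 3 percentage points lower from compound 1 to compound 3 (within the scatter) in this assay. Going by these compounds alone, this is the first reading of a single change on the core of compound 1, which compound 2 could not give, as it differs from compound 1 in more than one place. With the core held fixed, 5-hydroxypentyl stands in for 2-hydroxyethyl on the amide with no difference that this read-out can separate from the scatter.

As far as these compounds go, whether an amine or a carboxylic acid in place of the hydroxy of 5-hydroxypentyl, or a longer chain, would leave the number where it stands remains open. No measurement shown here offers any explanation for this result.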